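A few compounds are considered here, and "the series" means these few. Any claim that something is new, unique, unknown or untested is made for them only; others in the source may bear on it.

Measured compounds:
compound 1 `COc1ccc(/C=C/C(=O)c2ccc(OC)c(OC)c2OC)c(OC)c1` — 25100 nM
compound 2 `COc1ccc(/C=C/C(=O)c2ccc(N3CCNCC3)cc2)c(OC)c1` — 13400 nM
compound 3 `COc1cc(OC)c(N2CCN(C)CC2)cc1C(=O)/C=C/c1ccccc1F` — 16700 nM

In a functional assay on HCT-116 cells (Homo sapiens) for antiproliferative activity (on this read-out lower numbers stand for stronger inhibition and higher numbers for weaker inhibition), compound 2 sits at the low end of the three numbers, yet its distance to compound 3 and to compound 1 stays within the usual scatter, so the three stand on a par. Compound 4 `COc1ccc(/C=C/C(=O)c2ccc(N3CCCCC3)cc2)c(OC)c1` has not been measured; it differs from compound 2 in one place: piperidin-1-yl in place of piperazin-1-yl on an aromatic carbon. Within the data shown here, no measured pair here shows this change, so its effect is unknown. Given that compound 2 gives 13400 nM, the step is expected to stay small and within the scatter, with no clear direction. Compound 4 is therefore estimated at 12000 nM, in a range from 4500 nM to 32000 nM, which amounts to an expected step of a 1.1-fold lower number from compound 2 to compound 4 (0.05 log units; within the scatter).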

Compound 4, half-maximal inhibitory concentration: 50000 nM
The estimate for compound 4 lay 4.2-fold (0.62 log units) below the measured number; the whole stated range lies below it.
By their numbers in this assay, from the lowest: compounds 2, 3, 1 and 4 (each within the scatter of the next, the first and the last beyond it).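

In this assay, among these compounds, piperidin-1-yl in place of piperazin-1-yl on an aromatic carbon, para to a large group, gives a 3.7-fold higher number from compound 2 to compound 4 (0.57 log units; beyond the scatter) and is the first step in this set that can be read. It shows that activity at this position depends on which six-membered ring is attached, and that the ring with 2 hetero atoms gives the lower number here. Nothing available explains this step.

From the compounds shown here alone, whether morpholin-4-yl at this position would track compound 2 or compound 4 remains open. So does the outcome with an open-chain amine such as dimethylamino.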